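Thiophene for phenyl at the end of the dienone chain

The compounds below may be only part of what the source reports. "The series", "measured", "known", "first", "only" and "open" are said of these compounds alone.

Measured compounds in a functional assay on COLO 205 cells (Homo sapiens) for inhibition, read by sulforhodamine B assay, with a stated time of 48 h, tested at 50 uM; a higher number here means more inhibition of growth at the concentration tested, a lower number less inhibition of growth:
- compound 1, `COc1cc(/C=C/C(=O)/C=C/c2ccccc2)ccc1OCc1cn(CCCOc2cc(=O)oc3ccccc23)nn1`: 43%
- compound 2, `COc1ccc(/C=C/C(=O)/C=C/c2ccc(OCc3cn(CCOc4cc(=O)oc5ccccc45)nn3)c(OC)c2)cc1`: 68%
- compound 3, `COc1cc(/C=C/C(=O)/C=C/c2cccc3ccccc23)ccc1OCc1cn(CCOc2cc(=O)oc3ccccc23)nn1`: 85%

Compound 1 gives the lowest of the three numbers in this assay; compound 2 lies beyond the scatter above it, and compound 3 further still. Going by the values given here, the one single-point step among the measured compounds is a number 17 percentage points higher from compound 2 to compound 3 (beyond the scatter), where the swap is naphthalen-1-yl in place of 4-methoxyphenyl at the same place on the chain that is changed here.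

The unmeasured compound 4, `COc1cc(/C=C/C(=O)/C=C/c2cccs2)ccc1OCc1cn(CCCOc2cc(=O)oc3ccccc23)nn1`, differs from compound 1 as follows: thiophen-2-yl in place of phenyl on a double-bonded chain carbon bound to a double-bonded chain carbon. Among the compounds with values here, no measured step bears on this particular swap; the step from compound 2 to compound 3 concerns a different pair of groups, so it offers only the hint that this place on the chain can move the read-out. Within the data shown here, with no matching precedent, the expectation is a step from compound 1 to compound 4 of a number 2 percentage points higher from compound 1 to compound 4 (within the scatter), not beyond the scatter in either direction. Compound 4 is therefore estimated at 45% in this assay, with a range from 25% to 65%.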

Compound 4, percent growth inhibition at one concentration: 55%
Estimate against measurement, compound 4: 10 percentage points below, and the stated range covers the measured number.
By their numbers in this assay, from the lowest: compound 1; then compound 4; then compound 2; then compound 3.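

In this assay, replacing phenyl with thiophen-2-yl on a double-bonded chain carbon bound to a double-bonded chain carbon gives a number 12 percentage points higher from compound 1 to compound 4 (beyond the scatter). Going by these compounds alone, this is the first measured step at this place that starts from plain phenyl, and it shows that a five-membered aromatic ring holding one sulfur atom can stand in for the six-membered carbon ring without the number falling. Nothing measured here explains why the number rises with this swap.

The compounds shown leave open whether thiophen-3-yl, or furan-2-yl with oxygen in place of sulfur, would behave like thiophen-2-yl at this place. They also leave open whether the same swap would give a similar step on the linking chain that compound 3 carries.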